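Substituting the terminal nitrogen of compound 3

The source may hold more compounds than are shown below. What is called first, only, known or untested is meant among the compounds shown, and "the series" means these compounds.

Among the measured compounds shown here, in a functional assay on HT-29 cells (Homo sapiens) for antiproliferative activity, read by sulforhodamine B assay, with a stated time of 72 h (a lower number here means a stronger inhibitor, a higher number a weaker inhibitor), compound 3 (`NC(=S)N/N=C/c1ccc2ccccc2n1`) gives 100000 nM, the highest number of the three measured so far. Compound 1 (`CN(C)C(=S)N/N=C/c1cc2cccnc2s1`), whose core differs from the one shared by the other compounds, gives 13400 nM. Compound 2 (`CN(C)C(=S)N/N=C/c1ccc2ccccc2n1`) gives 20 nM.

The next compound is compound 4 (`S=C(N/N=C/c1ccc2ccccc2n1)Nc1cccc(Cl)c1`). It differs from compound 3 as follows: 3-chlorophenyl in place of hydrogen on an amide-type nitrogen. Thus 3-chlorophenyl stands in place of hydrogen on an amide-type nitrogen whose other neighbour is the thiocarbonyl carbon.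

For the measured compounds named here, only one measured step bears on this change: a 5000-fold higher number from compound 2 to compound 3 (3.70 log units; beyond the scatter). This large step, with amino in place of dimethylamino on a thiocarbonyl carbon, shows that the read-out on the shared core can respond strongly to what this nitrogen carries. Going by the values given here, it is a single pair, however, and no measured compound has a 3-chlorophenyl group there, so neither the size nor the direction of the new step is fixed by the data.

A partial return towards compound 2, at 20 nM, is the working expectation, and the range is kept wide. The expected step is a 100-fold lower number from compound 3 to compound 4 (2.00 log units; beyond the scatter). For compound 4 the estimate is 1000 nM, with an expected range of 100 nM to 15000 nM.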

Compound 4, half-maximal inhibitory concentration: 48100 nM
Compound 4: middle estimate off by 48-fold (1.68 log units), on the low side, outside the stated range (above it).
By their numbers in this assay, from the lowest: compound 2; then compound 1; then compound 4; then compound 3.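

With 3-chlorophenyl in place of hydrogen on the amide-type nitrogen, the result is a 2.1-fold lower number from compound 3 to compound 4 (0.32 log units; beyond the scatter) in this assay: a modest change, though beyond the scatter. Compound 4 at 48100 nM remains far from compound 2 at 20 nM, so the large step of a 5000-fold higher number from compound 2 to compound 3 (3.70 log units; beyond the scatter) does not mean that any group replacing hydrogen on this nitrogen on the shared core brings a low number, and the response now appears to depend on which group is attached. No measurement here accounts for the gap between the printed values of compound 2 and compound 4.

Going by these compounds, it remains open where a single methyl, an unsubstituted phenyl or a cyclic amine such as piperidine or morpholine on this nitrogen would fall between compound 2 and compound 4. Also open, on these data alone, is whether the chlorine of compound 4 contributes anything to its number, a question that the unsubstituted phenyl analogue or a methoxyphenyl analogue on the same nitrogen would help to settle.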